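The source may hold more compounds than are shown below. What is called first, only, known or untested is meant among the compounds shown, and "the series" means these compounds.

Compound 3 `CCCCCNC(=O)CC1CCc2cc(OC)c(OC)cc21` gives 71.7% in a functional assay on the whole organism (strain Swiss albino) for inhibition, with Mus musculus as the target, in the writhing test, with stated times of 60 min and 15 min, at a dose of 100 mg/kg by the oral route (on this read-out higher numbers stand for more inhibition at the one dose given (going by the name of the read-out) and lower numbers for less inhibition), the highest of the three numbers recorded so far. Compound 1 `COc1cc2c(cc1OC)C(CC(=O)N(C)C)CC2`, which bears dimethylamino on the carbonyl carbon, gives 22.6% in this assay, and compound 2 `CCNC(=O)CC1CCc2cc(OC)c(OC)cc21`, with ethylamino at that carbon, gives 23.6%. The step of a number 1 percentage points higher from compound 1 to compound 2 (within the scatter) stays within the scatter, whereas a number 49.1 percentage points higher from compound 1 to compound 3 (beyond the scatter) and a number 48.1 percentage points higher from compound 2 to compound 3 (beyond the scatter) are both large.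

Compound 4 `COc1cc2c(cc1OC)C(CC(=O)N1CCCC1)CC2` differs from compound 3 at the same carbonyl carbon: pyrrolidin-1-yl in place of pentylamino on a carbonyl carbon. The two steps that bear on this position, a number 49.1 percentage points higher from compound 1 to compound 3 (beyond the scatter) and a number 48.1 percentage points higher from compound 2 to compound 3 (beyond the scatter), both show that replacing dimethylamino or ethylamino with pentylamino raised the number markedly in this assay; no other change at this position has been measured. Compound 4 gives up pentylamino for a five-membered ring that carries no such chain, so the author expects the change to run the other way and to be large, a step of a number 43.7 percentage points lower from compound 3 to compound 4 (beyond the scatter) that brings compound 4 back toward the numbers of compound 1 and compound 2. The estimate for compound 4 in this assay is therefore 28%, with a range from 12% to 50%.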

Compound 4, a percentage reported as inhibition, in the whole organism at one dose (the size of the read-out at that dose, not a potency): 19.2%
The estimate for compound 4 lay 8.8 percentage points above the measured number, and the stated range covers the measured number.
By their numbers in this assay, from the lowest: compounds 4, 1 and 2 (each within the scatter of the next); then compound 3.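

With pyrrolidin-1-yl on the carbonyl carbon, this assay gives the first ring at this position, and the large step of a number 52.5 percentage points lower from compound 3 to compound 4 (beyond the scatter) shows that the high number of compound 3 does not carry over to this five-membered ring. The ring also stays within the scatter of both small open groups, with a number 4.4 percentage points lower from compound 2 to compound 4 (within the scatter) and a number 3.4 percentage points lower from compound 1 to compound 4 (within the scatter), so among the four groups at this position only pentylamino stands apart, while pyrrolidin-1-yl, ethylamino and dimethylamino cannot be told apart. Ethylamino carries the amide hydrogen and pyrrolidin-1-yl and dimethylamino do not, yet compounds 2, 1 and 4 lie within the scatter of one another, so the amide hydrogen alone does not set compound 3 apart, and no measurement offered here accounts for the result.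

The compounds shown leave open where between ethylamino and pentylamino the number rises, and whether it goes on rising with hexylamino or a longer chain. They also leave open whether pentylamino would hold its number without the amide hydrogen, as N-methylpentylamino would test, and whether a larger ring such as piperidin-1-yl would behave like pyrrolidin-1-yl.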